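The source may hold more compounds than are shown below. What is called first, only, known or untested is meant among the compounds shown, and "the series" means these compounds.

Among the compounds with values here, in a toxicity assay on MRC5 cells (Homo sapiens) for inhibition, read by MTT assay, with a stated time of 72 h (on this read-out higher numbers stand for weaker inhibition and lower numbers for stronger inhibition), compound 2 (`CCCCCC(=O)OCCc1ccc(O)cc1`) gives 166000 nM, the only exact number so far. Compound 1 (`CCCCCCCCCCCCCC(=O)OCCc1ccc(O)c(O)c1`) gives > 50000 nM, which is a limit. Compound 3 (`CCCCCCCCCCC(=O)OCCc1ccc(O)c(O)c1`) gives > 50000 nM, which is also a limit. Compound 4 (`CCCCCCCC(=O)OCCc1ccc(O)cc1`) differs from compound 2 by one change: ethyl in place of hydrogen on a saturated chain carbon, five bonds along the chain from a carbonyl carbon. In words, this is ethyl in place of hydrogen on a saturated chain carbon, five bonds along the chain from a carbonyl carbon. Within the data shown here, the one measured step, a step that the two limits leave unreadable from compound 1 to compound 3, offers neither a size nor a direction to build on, so no shift beyond the scatter is expected in this assay. The expected change is a 1.3-fold lower number from compound 2 to compound 4 (0.11 log units; within the scatter). For compound 4 the estimated value is 130000 nM, with an expected range of 50000 nM to 300000 nM.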

Compound 4, half-maximal inhibitory concentration: 133000 nM
Beside the measured number, compound 4's estimate is 1.0-fold (0.01 log units) below it; measured number inside the range.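

In this assay, ethyl in place of hydrogen on a saturated chain carbon, five bonds along the chain from a carbonyl carbon, gives a 1.2-fold lower number from compound 2 to compound 4 (0.10 log units; within the scatter). Within the data shown here, this is the only step with a readable size, and it shows that adding ethyl at this position does not move the number beyond the usual scatter. The step joining compound 1 and compound 3 cannot be read, as both values are limits: the limit of > 50000 nM in this assay, at which 2 of the 4 values shown sit.

Going by these compounds, whether an amine, a carboxylic acid or a longer chain at this position would move the number beyond the scatter stays open. A single readable step sets no trend.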